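Ring-closed alcohol in place of the open tertiary alcohol

A few compounds are considered here, and "the series" means these few. Any claim that something is new, unique, unknown or untested is made for them only; others in the source may bear on it.

Two members of this series carry numbers in an assay on HEK293 cells for inhibition of Leucine-rich repeat serine/threonine-protein kinase 2 (Homo sapiens), with a stated time of 48 h; on this read-out higher numbers stand for weaker inhibition and lower numbers for stronger inhibition. Compound 1 `Cc1nn(CC(C)(C)O)cc1Nc1nc(N)c2c(C#N)c(N3CCC[C@H]3C)n(C)c2n1` gives 280 nM in this assay, and compound 2 `Cc1c(Nc2nc(N)c3c(C#N)c(N4CCC[C@H]4C)n(C)c3n2)cnn1C1COC1` gives 300 nM. Compound 1 holds the lower of the two numbers, but the gap to compound 2 is within the scatter, so the two cannot be told apart on this read-out. For the measured compounds named here, no pair of measured compounds differing in a single place exists in the set, so the series itself says nothing yet about how sensitive this region is to change.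

Compound 3 `Cc1nn(CC2(O)COC2)cc1Nc1nc(N)c2c(C#N)c(N3CCC[C@H]3C)n(C)c2n1` is not yet measured. It differs from compound 1 by 3-hydroxyoxetan-3-yl in place of 1-hydroxy-1-methylethyl on a saturated chain carbon bound to an aromatic nitrogen; the shared core of compound 1 and the link to the aromatic nitrogen are kept, and the two methyl groups of the carbinol are tied into the oxetane ring, which adds one hydrogen-bond acceptor.

Given that compound 1 at 280 nM and compound 2 at 300 nM bear quite different substituents on the same aromatic nitrogen yet sit within the scatter of each other, only a small step is expected here, a 1.1-fold higher number from compound 1 to compound 3 (0.03 log units; within the scatter), with no direction beyond the scatter. Compound 3 is therefore estimated at 300 nM, with a range from 120 nM to 750 nM.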

Compound 3, half-maximal inhibitory concentration: 410 nM
Beside the measured number, compound 3's estimate is 1.4-fold (0.14 log units) below it; the measured number falls inside the stated range.
By their numbers in this assay, from the lowest: compounds 1, 2 and 3 (each within the scatter of the next).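

Tying the two methyl groups of the carbinol into the oxetane ring gives the first single-place step in the series: in this assay, 3-hydroxyoxetan-3-yl in place of 1-hydroxy-1-methylethyl gives a 1.5-fold higher number from compound 1 to compound 3 (0.17 log units; within the scatter), so the two compounds cannot be told apart on this read-out. On this one step, the substituent on the saturated chain carbon bound to an aromatic nitrogen accepts the added four-membered ring and the additional hydrogen-bond acceptor with no difference beyond the scatter, though the hydrogen-bond donor count is the same on both sides and the step therefore does not test the hydroxyl itself. Nothing measured here bears on the reason for this result.

As far as these compounds go, whether the hydroxyl is needed at all remains open: a plain 2-methylpropyl chain, a 2-methoxy-2-methylpropyl chain or a (3-aminooxetan-3-yl)methyl group on the same core would address that. Also open, from the compounds shown here alone, is whether a larger ring such as a 4-hydroxytetrahydropyran-4-yl group, or a carboxylic acid at this place, would move the number beyond the scatter.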